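From compound 2 to compound 3 in a series at the limit

A few compounds are considered here, and "the series" means these few. Any claim that something is new, unique, unknown or untested is made for them only; others in the source may bear on it.

Measured so far:
compound 1 `CC(C)(C)OC(=O)N1CCN(C(=S)SCc2cn(C[C@H](O)[C@H]3OC(=O)C(OCc4ccccc4)=C3OCc3ccccc3)nn2)CC1` — in a functional assay on SW-620 cells (Homo sapiens) for antiproliferative activity, read by MTT assay, with a stated time of 72 h (on this read-out lower numbers stand for stronger inhibition and higher numbers for weaker inhibition), compound 1 gives only the limit > 100000 nM.
compound 2 `COc1ccccc1-c1cn(C[C@H](O)[C@H]2OC(=O)C(OCc3ccccc3)=C2OCc2ccccc2)nn1` — in this assay compound 2 gives only the limit > 100000 nM.

Neither value is a number: both are limits of the assay. Compound 2 therefore stands nowhere in particular on the numbers shown, since both measured compounds sit at the limit of > 100000 nM in this assay, at which 2 of the 2 values shown sit. Among the measured compounds shown here, no step between measured compounds can be read from this, and no value below that limit has been seen.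

Compound 3 `Cc1ccc(S(=O)(=O)NCc2cn(C[C@H](O)[C@H]3OC(=O)C(OCc4ccccc4)=C3OCc3ccccc3)nn2)cc1` differs from compound 2 at one place: (((4-methylphenyl)sulfonyl)amino)methyl in place of 2-methoxyphenyl on an aromatic carbon. Nothing in the shown data suggests that this change moves the read-out beyond the scatter, so the expected step in this assay is none beyond the scatter, and a limit is again the likeliest report. Compound 3 is expected at 100000 nM, with a range from 30000 nM to 300000 nM. This expectation corresponds to a step of a number no higher from compound 2 to compound 3 (the limit leaves the size open).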

Compound 3, half-maximal inhibitory concentration: 45800 nM
Estimate against measurement, compound 3: 2.2-fold (0.34 log units) above; the measured number falls inside the stated range.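

In this assay, putting (((4-methylphenyl)sulfonyl)amino)methyl in place of 2-methoxyphenyl gives an at least 2.1-fold lower number from compound 2 to compound 3 (0.33 log units; beyond the scatter). This shows that the group on this aromatic carbon of the five-membered aromatic ring can bring the read-out to a measurable number, so the shared core does not hold every compound at the limit of the assay. Compound 3 is the only compound shown with a number, and the other two values are limits, so the step has a lower bound but no known full size: the limit of > 100000 nM in this assay, at which 2 of the 3 values shown sit.

Which part of the entering group goes with the step cannot be told from these compounds, as the sulfonyl, the amino hydrogen and the 4-methylphenyl ring all arrive together. From the compounds shown here alone, whether an amine, a carboxylic acid or a longer chain on this carbon would give a lower number also stays open.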